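From tert-butyl to 1-hydroxy-1-methylethyl on the shared core

The compounds below may be only part of what the source reports. "The series", "measured", "known", "first", "only" and "open" are said of these compounds alone.

Compound 1 `CC(C)c1ccc(Nc2ccc(C(=O)C(Cl)Cl)cc2[N+](=O)[O-])cc1` gives 1500 nM
Compound 2 `CC(C)(C)c1ccc(Nc2ccc(C(=O)C(Cl)Cl)cc2[N+](=O)[O-])cc1` gives 5900 nM

In an ADME assay on L02 cells (Homo sapiens) for cytotoxicity, read by MTT assay, with a stated time of 72 h (a higher number here means a weaker inhibitor, a lower number a stronger inhibitor), compound 2 stands highest of the two measured, at 5900 nM against the lower number of compound 1. Compound 3 `CC(C)(O)c1ccc(Nc2ccc(C(=O)C(Cl)Cl)cc2[N+](=O)[O-])cc1` carries one change from compound 2, namely hydroxy in place of methyl on a saturated chain carbon bound to an aromatic carbon and two saturated chain carbons in short, hydroxy in place of methyl on a saturated chain carbon bound to an aromatic carbon and two saturated chain carbons. Within the data shown here, only one measured step bears on this carbon, a 3.9-fold higher number from compound 1 to compound 2 (0.59 log units; beyond the scatter) on methyl replacing hydrogen there. That step shows nothing directly about a hydroxy, so only a small step is expected in this assay and, if it shows at all, towards a higher number. The expected move is a 1.5-fold higher number from compound 2 to compound 3 (0.18 log units; within the scatter) on this reasoning. For compound 3 an expected 9000 nM is estimated, with 3000 nM to 27000 nM as its range.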

Compound 3, half-maximal inhibitory concentration: 7800 nM
Compound 3: middle estimate off by 1.2-fold (0.06 log units), on the high side; the range from low to high includes it.
By their numbers in this assay, from the lowest: compound 1; then compounds 2 and 3 (each within the scatter of the next).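

In this assay, hydroxy in place of methyl on this saturated chain carbon gives a 1.3-fold higher number from compound 2 to compound 3 (0.12 log units; within the scatter), so compound 2 and compound 3 cannot be told apart, although hydroxy brings a hydrogen-bond donor and a hydrogen-bond acceptor that methyl lacks. Measured against the hydrogen of compound 1, hydroxy gives a 5.2-fold higher number from compound 1 to compound 3 (0.72 log units; beyond the scatter), and methyl gives a 3.9-fold higher number from compound 1 to compound 2 (0.59 log units; beyond the scatter), so among these three compounds only compound 1 stands apart. No other measurement bears on this result.

On these data alone, whether an amine or a carboxylic acid on this carbon would read like compound 2 and compound 3 or lie nearer compound 1 stays open, as does the effect of a longer chain in place of methyl. Also open, as far as these compounds go, is whether hydroxy in place of methyl would give so small a step on any other core.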